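The source may hold more compounds than are shown below. What is called first, only, known or untested is meant among the compounds shown, and "the series" means these compounds.

Measured in a functional assay on HCT-116 cells (Homo sapiens) for cytotoxicity, read by MTT assay, with a stated time of 72 h; a lower number here means a stronger inhibitor, a higher number a weaker inhibitor:
- compound 1 `CCCCN1CCN(CCCCn2c3c(c4ccccc42)C(=O)c2c[n+]([O-])c4ccccc4c2C3=O)CC1`: 1920 nM
- compound 2 `CN1CCN(CCCCCCn2c3c(c4ccccc42)C(=O)c2c[n+]([O-])c4ccccc4c2C3=O)CC1`: 2900 nM

Only these two compounds have been measured, and compound 2 lies within the scatter of compound 1, as a 1.5-fold higher number from compound 1 to compound 2 (0.18 log units; within the scatter) shows. The next compound is compound 3 `O=C1c2c[n+]([O-])c3ccccc3c2C(=O)c2c1c1ccccc1n2CCCN1CCC(O)CC1`, and its difference from compound 2 is 4-hydroxypiperidin-1-yl in place of 3-(4-methylpiperazin-1-yl)propyl on a saturated chain carbon, three bonds along the chain from an aromatic nitrogen. In words, it carries 4-hydroxypiperidin-1-yl in place of 3-(4-methylpiperazin-1-yl)propyl on a saturated chain carbon, three bonds along the chain from an aromatic nitrogen.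

Going by the values given here, one measured step bears on this change, and only in part. The step of a 1.5-fold higher number from compound 1 to compound 2 (0.18 log units; within the scatter) also replaced a group on the chain, and it did not leave the scatter. Neither measured compound carries 4-hydroxypiperidin-1-yl, so the data offer no direct evidence for that group. No step beyond the scatter is therefore expected in this assay, and no firm direction can be assigned, although the uncertainty remains wide. The expected change is a 1.2-fold lower number from compound 2 to compound 3 (0.06 log units; within the scatter). Compound 3 is estimated at 2500 nM, with an expected range of 1000 nM to 6500 nM.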

Compound 3, half-maximal inhibitory concentration: 190 nM
Compound 3: the middle estimate sits 13-fold (1.12 log units) above what was measured; the whole stated range lies above it.
By their numbers in this assay, from the lowest: compound 3; then compounds 1 and 2 (each within the scatter of the next).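

In this assay, going by these compounds alone, the chain position, which had so far moved only within the scatter, now gives a large change: with 4-hydroxypiperidin-1-yl in place of 3-(4-methylpiperazin-1-yl)propyl, there is a 15-fold lower number from compound 2 to compound 3 (1.18 log units; beyond the scatter). The same holds against the butyl-substituted piperazine, with a 10-fold lower number from compound 1 to compound 3 (1.00 log units; beyond the scatter), so the result does not rest on a single reference compound, and compound 3 stands as the strongest inhibitor of the three. Nothing in the data shown accounts for the size of these steps.

The compounds shown leave open which part of the change matters, since the ring, the hydroxyl group and the length of the chain all differ together between compound 3 and the other two compounds. A plain piperidine, or a 4-methylpiperazin-1-yl group, on the chain of compound 3 would separate the hydroxyl group and the ring from the chain length, and a 4-methoxypiperidin-1-yl group would show whether the hydroxyl hydrogen itself is needed.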